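Methoxy for Fluoro on the Aryl Group of Compound 1

This account rests on a few compounds, and the source may have more. Where it says the series, first, only, none or still open, it means among the compounds named here.

Measured so far:
compound 1 `Cc1cc(C(=O)O)c(C)n1-c1cccc(F)c1` — 1500 nM
compound 2 `Cc1ccccc1-n1c(C)cc(C(=O)O)c1C` — 2200 nM
compound 3 `Cc1ccc(-n2c(C)cc(C(=O)O)c2C)cc1` — 2000 nM

The three compounds share one core and differ only in the substitution of the aryl group on the ring nitrogen. In an assay on cells for inhibition of Palmitoleoyl-protein carboxylesterase NOTUM variant C330S (Homo sapiens), read by fluorescence, with a stated time of 40 min (on this read-out higher numbers stand for weaker inhibition and lower numbers for stronger inhibition), compound 1 gives 1500 nM, the lowest of the three numbers, yet compound 3 at 2000 nM and compound 2 at 2200 nM both sit within the usual scatter of that figure, so no order among the three can be claimed. Going by the values given here, no single-point step between measured compounds is available from this set.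

Compound 4 `COc1cccc(-n2c(C)cc(C(=O)O)c2C)c1` is the next compound. It differs from compound 1 as follows: methoxy in place of fluoro on an aromatic carbon. Since the three measured aryl variants all fall close together in this assay, the change is expected to give no step beyond the scatter. The estimate for compound 4 in this assay is 1800 nM, with a range from 600 nM to 5500 nM. This expected value corresponds to a step of a 1.2-fold higher number from compound 1 to compound 4 (0.08 log units; within the scatter).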

Compound 4, half-maximal inhibitory concentration: 1500 nM
Beside the measured number, compound 4's estimate is 1.2-fold (0.08 log units) above it; measured number inside the range.
By their numbers in this assay, from the lowest: compounds 1, 4, 3 and 2 (each within the scatter of the next).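

Methoxy in place of fluoro on this aromatic carbon, meta to a large group, gives in this assay no change at the digits printed from compound 1 to compound 4 (within the scatter). Going by these compounds alone, this is the first step in the set that changes one group at one place, and it shows that this position takes methoxy, with two heavy atoms and one hydrogen-bond acceptor, in place of fluoro, with one heavy atom and none, without a step beyond the scatter. Nothing available here gives a measured reason for this result.

From the compounds shown here alone, it remains open whether an amine, a carboxylic acid or a longer chain such as butoxy at this place would move the number beyond the scatter. Going by these compounds, it is also open whether methoxy would give the same result elsewhere on the aromatic ring.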